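Acyl substitution on the aromatic amine of compound 1

The source may report more compounds than this note shows. Statements on the series, on what has been measured and on what is new or still open speak of the compounds shown alone.

Compound 1, `COc1ccc(C(=O)c2cc(OC)c(OC)c(OC)c2)cc1N`, gives 30 nM in a functional assay on B16 cells (Mus musculus) for cytotoxicity, read by MTT assay, with a stated time of 72 h; on this read-out higher numbers stand for weaker inhibition and lower numbers for stronger inhibition.
Compound 2, `COc1ccc(C(=O)c2cc(OC)c(OC)c(OC)c2)cc1NC(=O)/C=C/c1ccc(C(F)(F)F)cc1`, gives 100 nM in this assay.
Compound 3, `COc1ccc(C(=O)c2cc(OC)c(OC)c(OC)c2)cc1NC(=O)/C=C/c1ccc(F)c(F)c1`, gives 6500 nM in this assay.

Compound 1 stands at the lowest number of the three; compound 2 and compound 3 both lie above it beyond the scatter. Compound 4, `COc1ccc(C(=O)c2cc(OC)c(OC)c(OC)c2)cc1NC(=O)/C=C/c1ccc(N)cc1`, differs from compound 1 by (2-(4-aminophenyl)ethenyl)carbonyl in place of hydrogen on a nitrogen on an aromatic ring. Among the compounds with values here, the one counted step, a 65-fold higher number from compound 2 to compound 3 (1.81 log units; beyond the scatter), shows that the substituent on the aryl ring of the acyl chain moves the number strongly, and no measured compound carries the aminophenyl group. Both acylated compounds give higher numbers than compound 1, so a weaker result is expected for compound 4, with a wide range because of a 65-fold higher number from compound 2 to compound 3 (1.81 log units; beyond the scatter). The estimate for compound 4 is 300 nM, between 50 nM and 4000 nM, an expected step of a 10-fold higher number from compound 1 to compound 4 (1.00 log units; beyond the scatter).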

Compound 4, half-maximal inhibitory concentration: 7900 nM
The estimate for compound 4 lay 26-fold (1.42 log units) below the measured number; the measured number lies above the stated range.
By their numbers in this assay, from the lowest: compound 1; then compound 2; then compounds 3 and 4 (each within the scatter of the next).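

The (2-(4-aminophenyl)ethenyl)carbonyl group on the nitrogen gives a 260-fold higher number from compound 1 to compound 4 (2.42 log units; beyond the scatter) in this assay and is the largest step seen at this position. Amino in place of trifluoromethyl on an aromatic carbon gives a 79-fold higher number from compound 2 to compound 4 (1.90 log units; beyond the scatter) while 4-aminophenyl in place of 3,4-difluorophenyl gives a 1.2-fold higher number from compound 3 to compound 4 (0.08 log units; within the scatter), so among the acylated compounds only compound 2 stands apart. No evidence at hand bears on this result.

Still open, on these data alone, is whether a small acetyl group on the nitrogen stays close to compound 1, and how a chlorine or methoxy group on the aromatic carbon compares with trifluoromethyl.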